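Lengthening the chain: compound 1 to compound 3

A few compounds are considered here, and "the series" means these few. Any claim that something is new, unique, unknown or untested is made for them only; others in the source may bear on it.

Measured so far in a functional assay on L1210 cells (Mus musculus) for inhibition; on this read-out lower numbers stand for stronger inhibition and higher numbers for weaker inhibition
compound 1 (`CCOP(=O)(O)OC[C@H]1O[C@@H](n2ccc(N)nc2=O)[C@@H](O)[C@@H]1O`) 4 uM
compound 2 (`CCCCOP(=O)(O)OC[C@H]1O[C@@H](n2ccc(N)nc2=O)[C@@H](O)[C@@H]1O`) 7.5 uM

Only these two numbers are available in this assay, and compound 1 lies within the scatter of compound 2, so the two cannot be ranked. The next case is compound 3 (`CCCCCCOP(=O)(O)OC[C@H]1O[C@@H](n2ccc(N)nc2=O)[C@@H](O)[C@@H]1O`), and its difference from compound 1 is butyl in place of hydrogen on a saturated chain carbon, two bonds along the chain from an oxygen on an unsaturated carbon. The same difference reads ethoxy to hexyloxy.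

For the measured compounds named here, one measured step bears on this change: ethyl in place of hydrogen at the same place gave a 1.9-fold higher number from compound 1 to compound 2 (0.27 log units; within the scatter). That is a single step and it stays within the scatter, so it sets no trend and offers only a weak lean towards higher numbers as the chain grows. A modest move in that direction is therefore expected in this assay (a 2.5-fold higher number from compound 1 to compound 3 (0.40 log units; beyond the scatter)), although a result showing no step beyond the scatter would fit equally well. The estimate for compound 3 is 10 uM (expected range 3.5 uM to 30 uM).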

Compound 3, concentration for 50% inhibition: 7.8 uM
Compound 3: the middle estimate sits 1.3-fold (0.11 log units) above what was measured, within the range that was stated.
By their numbers in this assay, from the lowest: compounds 1, 2 and 3 (each within the scatter of the next).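

In this assay, butyl in place of hydrogen on a saturated chain carbon, two bonds along the chain from an oxygen on an unsaturated carbon, gives a 2.0-fold higher number from compound 1 to compound 3 (0.29 log units; within the scatter) and so stays within the scatter even with the change from ethoxy to hexyloxy. Ethyl in place of hydrogen on a saturated chain carbon, four bonds along the chain from an oxygen on an unsaturated carbon, gives a 1.0-fold higher number from compound 2 to compound 3 (0.02 log units; within the scatter) and adds nothing that can be read; the lean from the single earlier step does not become a trend, and compound 1, compound 2 and compound 3 cannot be ranked. Nothing at hand speaks to what lies behind this flat picture.

Going by these compounds, whether a longer chain, such as octyl or dodecyl, would give a step beyond the scatter at this position stays open. Also open, on these data alone, is how a branched chain, or a chain ending in an amine or a carboxylic acid, would read in this assay against the three compounds so far.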